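The source may report more compounds than this note shows. Statements on the series, on what has been measured and on what is new or still open speak of the compounds shown alone.

In a functional assay on HepG2 cells (Homo sapiens) for cytotoxicity (a higher number here means a weaker inhibitor, a lower number a stronger inhibitor), two compounds have been measured so far. Compound 1 `O=S(=O)(N/C(=N\O)Nc1ccc(Cl)cc1)c1cc2ccccc2s1` gives 176 ug/mL, and compound 2 `Cc1c(S(=O)(=O)/N=C(\S)Nc2ccc(Cl)cc2)sc2ccc(Cl)cc12` gives 57 ug/mL, which is the lower of the two numbers by a gap beyond the usual scatter of repeated measurements. Compound 3 `Cc1c(S(=O)(=O)/N=C(\S)Nc2ccc(Cl)c(Cl)c2)sc2ccc(Cl)cc12` matches compound 2 except for one edit, in which 4-chlorophenyl becomes 3,4-dichlorophenyl: chloro in place of hydrogen on an aromatic carbon. The new chloro takes the place of a hydrogen on an aromatic carbon, ortho to the chloro group already there. For the measured compounds named here, no two measured compounds differ in one place only, so the data offer no direct guide to this change, and the expectation is a loose one: a small move towards a lower number in this assay, possibly no larger than the scatter. The estimated step is a 1.3-fold lower number from compound 2 to compound 3 (0.10 log units; within the scatter). For compound 3 the expected value is 45 ug/mL, within an estimated range of 20 ug/mL to 100 ug/mL.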

Compound 3, half-maximal inhibitory concentration: 62 ug/mL
Estimate against measurement, compound 3: 1.4-fold (0.14 log units) below; measured number inside the range.
By their numbers in this assay, from the lowest: compounds 2 and 3 (each within the scatter of the next); then compound 1.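

In this assay, placing a chloro on the aromatic carbon ortho to the existing chloro group turns the 4-chlorophenyl of compound 2 into the 3,4-dichlorophenyl of compound 3, and this gives a 1.1-fold higher number from compound 2 to compound 3 (0.04 log units; within the scatter). For the compounds shown here, this is the first comparison that differs in one place only, and it shows that this added chloro produces no change that can be told apart from the ordinary spread of repeated measurements. Nothing available here offers an explanation for this result.

One added chloro cannot show whether this place is insensitive to substitution in general, so a methoxy group, an amine or a carboxylic acid there remains an open case. From the compounds shown here alone, it is also open how the series would respond to a phenyl ring carrying no chloro at all.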